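Three Aryl Ureas Pressed Against the Solubility Floor

This account rests on a few compounds, and the source may have more. Where it says the series, first, only, none or still open, it means among the compounds named here.

Compound 1 `O=C(Nc1ccc(F)c(C(F)(F)F)c1)Nc1ccccn1`: in a physicochemical assay for solubility, read by nephelometry, in phosphate buffer, measured as kinetic solubility, at pH 6.5 (a lower number here means a less soluble compound, a higher number a more soluble compound), compound 1 gives < 1.6 ug/mL, a limit of the assay rather than a number.
Compound 2 `N#Cc1ccc(NC(=O)Nc2ccc(F)c(C(F)(F)F)c2)cc1`: in this assay compound 2 gives < 1.6 ug/mL, again a limit.
Compound 3 `NC(=O)c1ccccc1NC(=O)Nc1ccc(F)c(C(F)(F)F)c1`: in this assay compound 3 gives 1.6 ug/mL.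

Compound 1 thus stands at the limit of < 1.6 ug/mL in this assay, at which 2 of the 3 values shown sit, so only a bound is known for it, and it cannot be set in order against compound 2 or compound 3. Compound 4 `Cc1cc(NC(=O)Nc2ccc(F)c(C(F)(F)F)c2)on1` is the step under study: 3-methyl-1,2-oxazol-5-yl in place of pyridin-2-yl on an amide-type nitrogen. The shared core of compound 1, the urea with its fluorine and trifluoromethyl bearing aryl group, is untouched. Going by the values given here, no pair of measured compounds differing at this position exists, so the size of the step is a matter of expectation only. The step of an at least 1.2-fold higher number from compound 1 to compound 4 (0.09 log units; that floor lies within the scatter) is expected to be small, a change not clearly beyond the scatter, if anything a slight rise. Compound 4 is therefore estimated at 2 ug/mL, within a range from 0.8 ug/mL to 6 ug/mL, with a real chance that the assay once more reports only a limit.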

Compound 4, solubility: 6.3 ug/mL
Estimate against measurement, compound 4: 3.2-fold (0.50 log units) below, outside the stated range (above it).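

In this assay, the group on the amide-type nitrogen proves able to lift a compound clear of the floor: 3-methyl-1,2-oxazol-5-yl in place of pyridin-2-yl gives an at least 3.9-fold higher number from compound 1 to compound 4 (0.59 log units; beyond the scatter). Going by these compounds alone, this is the first readable step at this position, and the shared core stays untouched across it. Its full size remains unknown because compound 1 carries only a limit of the assay, not a number: the limit of < 1.6 ug/mL in this assay, at which 2 of the 4 values shown sit.

The change replaces the ring, its hetero atoms and the methyl together, so this single step cannot show which of these accounts for the rise. Also open, on these data alone, is how far the number would move with an amine or a carboxylic acid in place of the methyl on the 3-methyl-1,2-oxazol-5-yl group.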